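This account rests on a few compounds, and the source may have more. Where it says the series, first, only, none or still open, it means among the compounds named here.

Measured compounds and their values in a functional assay on isolated protein for agonist activity at Glucose-dependent insulinotropic receptor (Rattus norvegicus), read by HTRF and cAMP accumulation; a lower number here means a smaller maximal response, a higher number a larger maximal response:
compound 1 `CC(C)OC(=O)N1CCC(O[C@H]2CC[C@H](Oc3cnc(S(C)(=O)=O)cn3)CC2)CC1`, giving 120%
compound 2 `C[C@@H](CF)OC(=O)N1CCC(O[C@H]2CC[C@H](Oc3cnc(S(C)(=O)=O)cn3)CC2)CC1`, giving 123%
compound 3 `CS(=O)(=O)c1cnc(O[C@H]2CC[C@H](OC3CCN(C(=O)C4(C(F)(F)F)CC4)CC3)CC2)cn1`, giving 140%

Compound 3 stands highest of the three numbers in this assay. Its nearest neighbour is compound 2, with a step of a number 17 percentage points higher from compound 2 to compound 3 (beyond the scatter); its furthest is compound 1, with a step of a number 20 percentage points higher from compound 1 to compound 3 (beyond the scatter). Compound 1 and compound 2 lie together, their step being a number 3 percentage points higher from compound 1 to compound 2 (within the scatter).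

Compound 4 `CS(=O)(=O)c1cnc(O[C@H]2CC[C@H](OC3CCN(CC4(C(F)(F)F)CC4)CC3)CC2)cn1` differs from compound 3 in one place: (1-(trifluoromethyl)cyclopropyl)methyl in place of (1-(trifluoromethyl)cyclopropyl)carbonyl on an amine nitrogen in a ring. Among the measured compounds shown here, none of the measured steps covers this kind of change. Each of them swaps the group on the carbonyl carbon while the carbonyl itself stays, and the larger of those steps, a number 20 percentage points higher from compound 1 to compound 3 (beyond the scatter) and a number 17 percentage points higher from compound 2 to compound 3 (beyond the scatter), moved the maximal response upward by a modest amount. Nothing measured tells what happens when the carbonyl is taken away. The estimate for compound 4 therefore leans on compound 3 alone, with a wide range. A step of a number 20 percentage points lower from compound 3 to compound 4 (beyond the scatter) is expected, a modest downward drift from the high point of compound 3. Compound 4 is estimated at 120%, within a range from 90% to 150%.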

Compound 4, largest response reached (Emax), in percent of the reference or control that the assay uses: 124%
The estimate for compound 4 lay 4 percentage points below the measured number; measured number inside the range.
By their numbers in this assay, from the lowest: compounds 1, 2 and 4 (each within the scatter of the next); then compound 3.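

In this assay, the step of a number 16 percentage points lower from compound 3 to compound 4 (beyond the scatter) shows that the response at this ring nitrogen depends on the linking atom as well as on the group beyond it: the (1-(trifluoromethyl)cyclopropyl) part is retained, yet the (1-(trifluoromethyl)cyclopropyl)methyl compound does not keep the level reached with the carbonyl. The steps of a number 1 percentage points higher from compound 2 to compound 4 (within the scatter) and a number 4 percentage points higher from compound 1 to compound 4 (within the scatter) show that, without any carbonyl on this nitrogen, the response still stands level with those of the two isopropoxycarbonyl-type compounds. Nothing available here bears on the reason for this change.

Still open, on these data alone, is whether a sulfonyl or urea link on this nitrogen would match the amide link of compound 3. Also open, as far as these compounds go, is whether removing the carbonyl would have the same effect with a tert-butyl group in place of the 1-(trifluoromethyl)cyclopropyl part.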